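A Cyano for a Trifluoromethyl at the Far Phenyl Ring

This account rests on a few compounds, and the source may have more. Where it says the series, first, only, none or still open, it means among the compounds named here.

Compound 1 `CC(C)n1ncc2c(C(=O)NCc3cn(-c4ccccc4)nn3)cccc21` gives > 40000 nM in a functional assay on HepG2 cells (Homo sapiens) for inhibition, read by MTT assay, with a stated time of 72 h (on this read-out higher numbers stand for weaker inhibition and lower numbers for stronger inhibition), a limit of the assay.
Compound 2 `CC(C)n1ncc2c(C(=O)NCc3cn(-c4ccc([N+](=O)[O-])cc4)nn3)cccc21` gives > 40000 nM, again a limit.
Compound 3 `CC(C)n1ncc2c(C(=O)NCc3cn(Cc4ccc(C(F)(F)F)cc4)nn3)cccc21` gives > 40000 nM, also a limit.

Compound 3 thus stands at the limit where every shown value sits (the limit of > 40000 nM in this assay, at which 3 of the 3 values shown sit). Compound 4 `CC(C)n1ncc2c(C(=O)NCc3cn(Cc4ccc(C#N)cc4)nn3)cccc21` differs from it by cyano in place of trifluoromethyl on an aromatic carbon. Going by the values given here, the only step between measured compounds, a step that the two limits leave unreadable from compound 1 to compound 2, is a different change and cannot be read in size, both its ends being limits. Among the compounds with values here, no measured step bears on the trifluoromethyl-to-cyano exchange, so nothing points to movement beyond the scatter. The expected step for compound 4 is a step that the limit leaves unreadable from compound 3 to compound 4, essentially none. Compound 4 is therefore estimated at 60000 nM, within 20000 nM to 200000 nM, most likely reported again only as a limit.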

Compound 4, half-maximal inhibitory concentration: > 40000 nM
Compound 4: only a limit was reported; the forecaster's own chance of this, stated with the estimate: 85%; the middle value does not contradict the limit.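

No step from compound 1, compound 2 or compound 3 to compound 4 can be read, since all four values are only limits: the limit of > 40000 nM in this assay, at which 4 of the 4 values shown sit.

As far as these compounds go, how strongly each compound actually inhibits, and whether cyano and trifluoromethyl differ at all, stays open.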